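This account rests on a few compounds, and the source may have more. Where it says the series, first, only, none or still open, it means among the compounds named here.

Measured so far in a functional assay on NCI-H460 cells (Homo sapiens) for cytotoxicity, read by sulforhodamine B assay, with a stated time of 3 days (on this read-out higher numbers stand for weaker inhibition and lower numbers for stronger inhibition), for the series
compound 1 `O=Cc1cn(Cc2ccc(Cl)cc2)c2ccc(F)cc12` gives 290 nM
compound 2 `O=[N+]([O-])c1cccc(Cn2cc(CO)c3ccccc32)c1` gives 39 nM
compound 3 `OCc1cn(Cc2ccc(Cl)cc2)c2ccc(F)cc12` gives 30 nM

Compound 2 and compound 3 lie within the scatter of each other, and both numbers are well under that of compound 1. Compound 4 `COc1ccc2c(c1)c(CO)cn2Cc1ccc(Cl)cc1` differs from compound 3 by methoxy in place of fluoro on an aromatic carbon and is otherwise the same. For the measured compounds named here, the one measured step of a 9.7-fold lower number from compound 1 to compound 3 (0.99 log units; beyond the scatter) is beyond the scatter but concerns hydroxymethyl in place of formyl, so it does not size this change. Going by the values given here, no measured step touches the fluoro site. The expected move in this assay is a 1.3-fold higher number from compound 3 to compound 4 (0.12 log units; within the scatter) and so nothing beyond the scatter is expected. The estimate for compound 4 is 40 nM (expected range 12 nM to 130 nM).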

Compound 4, half-maximal inhibitory concentration: 1510 nM
Compound 4: middle estimate off by 38-fold (1.58 log units), on the low side, outside the stated range (above it).
By their numbers in this assay, from the lowest: compounds 3 and 2 (each within the scatter of the next); then compound 1; then compound 4.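

In this assay, the aromatic carbon carrying fluoro proves highly sensitive to substitution: methoxy in place of fluoro gives a 50-fold higher number from compound 3 to compound 4 (1.70 log units; beyond the scatter). The hydroxymethyl group, shared by compound 3 and compound 4, therefore does not secure a low number on its own in this core. Nothing measured here accounts for the size of this step. The compounds shown leave open whether other groups on this carbon, such as chloro, hydroxyl or an amine, behave like fluoro or like methoxy.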